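Swapping the Amide Cap of a Hydroxamic Acid

The source may report more compounds than this note shows. Statements on the series, on what has been measured and on what is new or still open speak of the compounds shown alone.

Of the compounds shown here, two have been tested in a functional assay on NFF cells (Homo sapiens) for antiproliferative activity; a lower number here means a stronger inhibitor, a higher number a weaker inhibitor. Compound 1, with the structure `CN(C)c1ccc(NC(=O)[C@H](CCCCCC(=O)NO)NC(=O)/C=C/c2ccccc2)cc1`, gives 240 nM. Compound 2, with the structure `CN(C)c1ccc(C(=O)N[C@@H](CCCCCC(=O)NO)C(=O)Nc2cccc3cccnc23)cc1`, gives 570 nM and so stands at the higher of the two numbers; the gap to compound 1 lies beyond the usual scatter, so compound 2 is the weaker inhibitor of the pair.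

Compound 3, with the structure `O=C(/C=C/c1ccccc1)N[C@@H](CCCCCC(=O)NO)C(=O)Nc1cccc2cccnc12`, is built from compound 2 by a single change: 2-phenylethenyl in place of 4-(dimethylamino)phenyl on a carbonyl carbon. Going by the values given here, the 2-phenylethenyl group entering here is the one carried by compound 1, which sits at the lower number. Among the compounds with values here, since no measured pair isolates this exact exchange, the expectation rests only on that comparison. A modest downward step in this assay is expected, as a 1.6-fold lower number from compound 2 to compound 3 (0.21 log units; within the scatter). Compound 3 is estimated to give 350 nM, with a range from 120 nM to 1000 nM.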

Compound 3, half-maximal inhibitory concentration: 1240 nM
For compound 3 the middle estimate is 3.5-fold (0.55 log units) below the measured one; the measured number lies above the stated range.
By their numbers in this assay, from the lowest: compound 1; then compound 2; then compound 3.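

On the carbonyl carbon, 2-phenylethenyl does not carry a lower number with it: in this assay its entry in place of 4-(dimethylamino)phenyl gives a 2.2-fold higher number from compound 2 to compound 3 (0.34 log units; beyond the scatter) rather than a drop. Compound 1 and compound 3 share 2-phenylethenyl, and quinolin-8-yl in place of 4-(dimethylamino)phenyl on an amide-type nitrogen gives a 5.2-fold higher number from compound 1 to compound 3 (0.71 log units; beyond the scatter) with that group unchanged. Both steps run the same way: among these three compounds, losing 4-(dimethylamino)phenyl from either place raises the number, and no compound shown goes against this.

No measurement shown bears on why either step goes upward.
Still open, as far as these compounds go, is whether the dimethylamino group itself matters or only the ring that carries it, a question that a plain phenyl or a 4-aminophenyl group at either place would address.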